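Swapping Fluoro for Chloro on Two Related Cores

The source may report more compounds than this note shows. Statements on the series, on what has been measured and on what is new or still open speak of the compounds shown alone.

Measured compounds:
compound 1 `C[C@@H]1CN(c2ccc(F)c(F)c2)CCN1C(=O)C(=O)Nc1ccc2[nH]c(=O)oc2c1`: 118%
compound 2 `C[C@@H]1CN(C(=O)C(=O)Nc2ccc3[nH]c(=O)oc3c2)CCN1c1ccc(F)c(F)c1`: 25.3%
compound 3 `C[C@@H]1CN(c2ccc(Cl)c(F)c2)CCN1C(=O)C(=O)Nc1ccc2[nH]c(=O)oc2c1`: 30.4%

In an ADME assay on the whole organism (Rattus norvegicus, strain Sprague-Dawley) for pharmacokinetics, using cassette dosing, at a dose of 1 mg/kg by the oral route (on this read-out lower numbers stand for lower oral bioavailability and higher numbers for higher oral bioavailability), compound 1 gives 118%, and the change to compound 3 chloro in place of fluoro on an aromatic carbon brings a number 87.6 percentage points lower from compound 1 to compound 3 (beyond the scatter). Compound 2 shares all its atoms with compound 1 but joins them differently; the difference between the two cores is not broken down here. In this assay compound 2 gives 25.3%, and compound 3 gives 30.4%, so the two values lie within the scatter of each other.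

Compound 4 `C[C@@H]1CN(C(=O)C(=O)Nc2ccc3[nH]c(=O)oc3c2)CCN1c1ccc(Cl)c(F)c1` is not yet measured. It differs from compound 2 by chloro in place of fluoro on an aromatic carbon, the same kind of change that turns compound 1 into compound 3, and the place line reads the same word for word in both cases. Within the data shown here, the one measured step of this change is large and downward. For compound 4 the step is expected to be much smaller, a number 15.3 percentage points lower from compound 2 to compound 4 (beyond the scatter), because compound 2 starts from 25.3% and oral bioavailability cannot fall below zero, whereas compound 1 started from 118%. Compound 4 is therefore estimated to give 10% in this assay, with a range from 2% to 30%.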

Compound 4, oral bioavailability: 32%
The estimate for compound 4 lay 22 percentage points below the measured number, outside the stated range (above it).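

In this assay, among these compounds, putting chloro in place of fluoro on the core of compound 2 brings a number 6.7 percentage points higher from compound 2 to compound 4 (within the scatter), so on this core the swap leaves no step that stands clear of the usual scatter. The same swap did not behave alike on the two cores, and a step seen on one could not simply be carried over to the other: the same change on two cores in this assay, a number 87.6 percentage points lower (beyond the scatter) from compound 1 to compound 3 and a number 6.7 percentage points higher (within the scatter) from compound 2 to compound 4, 94.3 percentage points apart, beyond the scatter of two such steps This shows that, for these two closely related cores, the outcome of the swap depends on the core that carries it, but it does not show why, and two pairs of compounds give no general rule for other cores or other swaps.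

On these data alone, only fluoro and chloro appear at this place, so how a bromo group, a methoxy group, a nitrile or an amine would fare there on either core remains open. Among the compounds shown here, also open is how much of the gap between the two steps rests on the single reading for compound 1, 118%, since each compound is represented here by one number.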